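The source may report more compounds than this note shows. Statements on the series, on what has been measured and on what is new or still open speak of the compounds shown alone.

Compound 1 `C=C1CC[C@@H]2[C@](C)(COC(C)=O)[C@H](O)CC[C@@]2(C)[C@@H]1C/C=C1/C(=O)OC[C@@H]1Oc1c(Cl)cc(Cl)c2cccnc12` gives 39300 nM in an ADME assay on SNB-19 cells (Homo sapiens) for cytotoxicity, read by MTT assay, with a stated time of 24 h; on this read-out higher numbers stand for lower toxicity in this test and lower numbers for higher toxicity in this test.
Compound 2 `C=C1CC[C@@H]2[C@](C)(COC(C)=O)[C@H](O)CC[C@@]2(C)[C@@H]1C/C=C1/C(=O)OC[C@H]1Oc1cccc2ccc(C)nc12` gives only a limit of the test, > 100000 nM, in this assay.
Compound 3 `C=C1CC[C@@H]2[C@](C)(CO)[C@H](O)CC[C@@]2(C)[C@@H]1C/C=C1/C(=O)OC[C@@H]1Oc1c(Cl)cc(Cl)c2cccnc12` also gives only a limit, > 100000 nM, in this assay.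

All three share a large steroid-like core carrying a lactone and an aromatic ether, and they differ in two ways. Compound 1 and compound 3 differ in one place only: hydrogen in place of acetyl on an oxygen on a saturated carbon. That change moved the read-out in this assay by an at least 2.5-fold higher number from compound 1 to compound 3 (0.40 log units; beyond the scatter), where the later value is a limit rather than a number. Compound 2 carries a different aromatic ether than compound 1; the difference between the two cores is not broken down here.

Compound 4 `C=C1CC[C@@H]2[C@](C)(CO)[C@H](O)CC[C@@]2(C)[C@@H]1C/C=C1/C(=O)OC[C@H]1Oc1cccc2ccc(C)nc12` is not yet measured. It stands to compound 2 as compound 3 stands to compound 1: hydrogen in place of acetyl on an oxygen on a saturated carbon. The place of the change is described in the same words in both pairs, so it is the same change made on a different core.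

Compound 2 already sits at the limit of the test, so no number is known from which a step could be measured. Going by the values given here, because two of the three known values sit at the limit of > 100000 nM in this assay, at which 2 of the 3 values shown sit, and because the one measured step of an at least 2.5-fold higher number from compound 1 to compound 3 (0.40 log units; beyond the scatter) raised the number, compound 4 is expected to remain at that limit, with the expected step from compound 2 being a step that the limit leaves unreadable from compound 2 to compound 4. For compound 4 the estimated value is 150000 nM, with a range from 60000 nM to 400000 nM.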

Compound 4, half-maximal cytotoxic concentration: > 100000 nM
Compound 4: no number, only a limit; the forecaster's own chance of this, stated with the estimate: 85%; the middle value does not contradict the limit.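

Compound 2 and compound 4 both stand at a limit of the test rather than at a number, so no size can be read for the change from acetoxymethyl to hydroxymethyl between them: the limit of > 100000 nM in this assay, at which 3 of the 4 values shown sit.

The compounds shown leave open how far past that limit compound 2 and compound 4 lie, and so whether this change acts on their core as it does on the core of compound 1.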